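Two compounds at the limit, a third still to be tested

The compounds below may be only part of what the source reports. "The series", "measured", "known", "first", "only" and "open" are said of these compounds alone.

Compound 1, `CC1CCN(C(=O)C(C)N2CCN(S(=O)(=O)c3ccc(C(C)(C)C)cc3)CC2)CC1`, in an ADME assay on HepG2 cells (Homo sapiens) for inhibition, with a stated time of 48 h (a lower number here means that less compound is needed, a higher number that more compound is needed for the effect), gives only the limit > 40000 nM.
Compound 2, `CC(C(=O)N1CCC(C)(C)CC1)N1CCN(S(=O)(=O)c2ccc(C(C)(C)C)cc2)CC1`, in this assay likewise gives only the limit > 40000 nM.

Compound 2 therefore stands nowhere definite on the numbers shown: it sits at the limit of this assay, with no number of its own and with compound 1 beside it at the same limit. Within the data shown here, the single measured step, a step that the two limits leave unreadable from compound 1 to compound 2, cannot be sized because the limit of > 40000 nM in this assay, at which 2 of the 2 values shown sit, covers both of its ends.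

Compound 3, `CC(C(=O)N1CCC2(CC1)CC2)N1CCN(S(=O)(=O)c2ccc(C(C)(C)C)cc2)CC1`, differs from compound 2 in one place: a group of 8 heavy atoms (7 carbon, 1 nitrogen; one three-membered non-aromatic ring of carbon only, one six-membered non-aromatic ring with 1 hetero atom) in place of a group of 8 heavy atoms (7 carbon, 1 nitrogen; one six-membered non-aromatic ring with 1 hetero atom), on a carbonyl carbon. Among the measured compounds shown here, no measured step bears on this change in a readable way, and the one step that exists gives neither size nor direction. The numbers offer no ground to expect compound 3 to come off the limit. Compound 3 is therefore expected to give 60000 nM, within a range of 20000 nM to 200000 nM. The expected step that the limit leaves unreadable from compound 2 to compound 3 amounts to nothing beyond the scatter, and the most likely outcome for compound 3 is a further limit rather than a number.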

Compound 3, half-maximal effective concentration: > 40000 nM
Compound 3 was reported as a limit (the forecaster's own chance of this, stated with the estimate: 85%); the middle value lies beyond the limit too.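

Compound 3 also gives only a limit and not a number, so its steps from compound 2 and from compound 1 cannot be read, in either size or direction: the limit of > 40000 nM in this assay, at which 3 of the 3 values shown sit.

The compounds shown leave open whether any group on the carbonyl carbon would give a readable number in this assay at all.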